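Thiophen-2-yl in place of 4-(trifluoromethyl)phenyl in compound 2

The source may hold more compounds than are shown below. What is called first, only, known or untested is meant among the compounds shown, and "the series" means these compounds.

Compound 1 `CS(=O)(=O)NC1CCC(CN2CCN(c3cc(=O)c4cc(C(F)(F)F)cc([N+](=O)[O-])c4s3)CC2)CC1` and compound 2 `O=C(OC1CCC(CN2CCN(c3cc(=O)c4cc(C(F)(F)F)cc([N+](=O)[O-])c4s3)CC2)CC1)c1ccc(C(F)(F)F)cc1` share one core. In an ADME assay on cells (Hepatocyte, Mus musculus) for metabolic stability (a higher number here means that the compound lasts longer, a lower number that the compound disappears faster), compound 1 gives > 1.55 h as a limit of the assay and not a number. Among the measured compounds shown here, compound 2 gives 0.278 h as the only actual number so far. Compound 3 `O=C(OC1CCC(CN2CCN(c3cc(=O)c4cc(C(F)(F)F)cc([N+](=O)[O-])c4s3)CC2)CC1)c1cccs1` differs from compound 2 by one exchange thiophen-2-yl in place of 4-(trifluoromethyl)phenyl on a carbonyl carbon with thiophen-2-yl in place of 4-(trifluoromethyl)phenyl on a carbonyl carbon. Measured steps for this exchange are lacking, so from compound 2 at 0.278 h no change beyond the scatter is expected in either direction. The expected step of a 1.1-fold higher number from compound 2 to compound 3 (0.03 log units; within the scatter) is small. Compound 3 is estimated at 0.3 h within a range from 0.12 h to 0.75 h for its half-life.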

Compound 3, half-life: 0.0867 h
Beside the measured number, compound 3's estimate is 3.5-fold (0.54 log units) above it; the whole stated range lies above it.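

At this carbonyl carbon, thiophen-2-yl in place of 4-(trifluoromethyl)phenyl gives in this assay a 3.2-fold lower number from compound 2 to compound 3 (0.51 log units; beyond the scatter), so the half-life responds to the group held there. On the saturated ring carbon, ((thiophen-2-yl)carbonyl)oxy in place of methanesulfonamido gives an at least 17-fold lower number from compound 1 to compound 3 (1.25 log units; beyond the scatter). That step is read against a limit and not a number: the limit of > 1.55 h in this assay, at which 1 of the 3 values shown sits.

Only two groups on this carbonyl carbon are shown, and they leave open whether the ring or the trifluoromethyl group accounts for the step. Plain phenyl at that carbon would separate the two.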